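Swapping a Pentan-3-yl Amine for a Methoxy-Bearing Chain

This account rests on a few compounds, and the source may have more. Where it says the series, first, only, none or still open, it means among the compounds named here.

Compound 1 `CCc1nc(-c2ccc(Cl)cc2Cl)c(CC)nc1NC(CC)CC` and compound 2 `CCc1nc(NC(CC)CC)c(Cl)nc1-c1ccc(Cl)cc1Cl` share a core and differ at one aromatic carbon, where compound 2 carries chloro in place of ethyl. In an in vitro ADME assay on microsomes (Homo sapiens) for metabolic stability (a lower number here means that the compound disappears faster, a higher number that the compound lasts longer), compound 1 gives 0.283 h. In this assay compound 2 gives 0.167 h. Among the compounds with values here, the one step measured, a 1.7-fold lower number from compound 1 to compound 2 (0.23 log units; within the scatter), stays within the scatter, so compound 1 stands with a single near neighbour and no number clearly apart from it.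

Compound 3 `CCc1nc(-c2ccc(Cl)cc2Cl)c(CC)nc1NC(COC)COC` follows from compound 1 by a change at a different place: 2-methoxy-1-(methoxymethyl)ethyl in place of pentan-3-yl on a nitrogen on an aromatic ring. Nothing measured speaks to this change; the step from compound 1 to compound 2 concerns an aromatic carbon, not the nitrogen on the aromatic ring. Without a measured guide, the expected step is a 1.0-fold lower number from compound 1 to compound 3 (0.00 log units; within the scatter), none beyond the scatter. Compound 3 is therefore expected to give 0.28 h in this assay, within 0.12 h to 0.65 h.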

Compound 3, half-life: 0.15 h
Compound 3: the middle estimate sits 1.9-fold (0.27 log units) above what was measured, and the stated range covers the measured number.
By their numbers in this assay, from the lowest: compounds 3, 2 and 1 (each within the scatter of the next).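

The nitrogen on the aromatic ring now has a measured step of its own: in this assay, 2-methoxy-1-(methoxymethyl)ethyl in place of pentan-3-yl gives a 1.9-fold lower number from compound 1 to compound 3 (0.28 log units; within the scatter). This step stays within the scatter, so a chain carrying oxygen atoms and hydrogen-bond acceptors, where pentan-3-yl has none, cannot be told apart from pentan-3-yl by this measurement. Nothing available explains the half-life seen for compound 3.

Going by these compounds, it remains open whether a cyclopentyl group, a longer chain or a chain bearing an amine on this nitrogen would give a number clearly apart from that of compound 1. Also open, on these data alone, is how chloro in place of ethyl on the aromatic carbon would read alongside the 2-methoxy-1-(methoxymethyl)ethyl chain.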